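A Pyrimidine Amide Replaces the Trifluoromethylphenyl Amide

The compounds below may be only part of what the source reports. "The series", "measured", "known", "first", "only" and "open" are said of these compounds alone.

Compound 3 `NC(=O)c1c(NC(=O)c2ccc(C(F)(F)F)cc2)sc2c1CCN(C(=S)Nc1ccccc1Cl)C2` gives 36100 nM in a functional assay on HL-60 cells (Homo sapiens) for antiproliferative activity, with a stated time of 24 h (a lower number here means a stronger inhibitor, a higher number a weaker inhibitor), the highest of the three measured numbers, so it is the weakest inhibitor of the set. Compound 1 `NC(=O)c1c(NC(=O)c2ccccc2)sc2c1CCN(C(=S)Nc1ccccc1Cl)C2` gives 13800 nM and compound 2 `NC(=O)c1c(NC(=O)c2ccccc2Br)sc2c1CCN(C(=S)Nc1ccccc1Cl)C2` gives 14600 nM; the steps were a 2.6-fold higher number from compound 1 to compound 3 (0.42 log units; beyond the scatter) and a 2.5-fold higher number from compound 2 to compound 3 (0.39 log units; beyond the scatter), while a 1.1-fold higher number from compound 1 to compound 2 (0.02 log units; within the scatter). Compound 4 `NC(=O)c1c(NC(=O)c2ccncn2)sc2c1CCN(C(=S)Nc1ccccc1Cl)C2` differs from compound 3 by pyrimidin-4-yl in place of 4-(trifluoromethyl)phenyl on a carbonyl carbon. Among the compounds with values here, no measured step exchanges the benzamide ring for a nitrogen-containing ring, so guidance is indirect; the two steps that reach compound 3 show that the trifluoromethyl-bearing ring carries the highest number, so removing it is expected to give a modest decrease, a 2.4-fold lower number from compound 3 to compound 4 (0.38 log units; beyond the scatter). Compound 4 is therefore estimated at 15000 nM, within 5000 nM to 45000 nM.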

Compound 4, half-maximal inhibitory concentration: 34600 nM
Beside the measured number, compound 4's estimate is 2.3-fold (0.36 log units) below it; low and high end bracket the measured number.
By their numbers in this assay, from the lowest: compounds 1 and 2 (each within the scatter of the next); then compounds 4 and 3 (each within the scatter of the next).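

In this assay, pyrimidin-4-yl takes the place of 4-(trifluoromethyl)phenyl with no readable change (a 1.0-fold lower number from compound 3 to compound 4 (0.02 log units; within the scatter)), so a high number at this carbonyl carbon is not confined to the trifluoromethyl-bearing ring. The phenyl and 2-bromophenyl amides remain the stronger inhibitors (a 2.5-fold higher number from compound 1 to compound 4 (0.40 log units; beyond the scatter); a 2.4-fold higher number from compound 2 to compound 4 (0.37 log units; beyond the scatter)). Nothing available explains why two such different rings give matching numbers. From the compounds shown here alone, whether a morpholine ring or a carboxylic acid on the phenyl ring could bring the number below that of the plain phenyl amide remains open.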